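Working notes: dimethylcarbamoyl in place of methyl on the core

A few compounds are considered here, and "the series" means these few. Any claim that something is new, unique, unknown or untested is made for them only; others in the source may bear on it.

For the measured compounds named here, compound 2 `Cc1ccc2c(c1)CC(C(=O)Nc1ccc(-c3cn[nH]c3)cc1)CO2` gives 10 nM in an assay on isolated protein for inhibition of Rho-associated protein kinase 2 (Homo sapiens) (a lower number here means a stronger inhibitor, a higher number a weaker inhibitor), the higher of the two numbers measured so far. Compound 1 `O=C(Nc1cc(F)c(-c2cn[nH]c2)c(F)c1)C1COc2ccccc2C1` gives 4 nM in this assay, a lower number, and the gap between compound 1 and compound 2 lies beyond the scatter. Compound 3 `CN(C)C(=O)c1ccc2c(c1)CC(C(=O)Nc1ccc(-c3cn[nH]c3)cc1)CO2` is the next member; it differs from compound 2 by dimethylcarbamoyl in place of methyl on an aromatic carbon. Going by the values given here, no measured pair carries this change, so the direction rests on nothing measured; a step of about the scatter, or none beyond it, is the expectation. Compound 3 is estimated at 15 nM, with a range from 4 nM to 60 nM. The expected step is a 1.5-fold higher number from compound 2 to compound 3 (0.18 log units; within the scatter).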

Compound 3, half-maximal inhibitory concentration: 86 nM
Beside the measured number, compound 3's estimate is 5.7-fold (0.76 log units) below it; measured number above the stated range.
By their numbers in this assay, from the lowest: compound 1; then compound 2; then compound 3.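

In this assay, for the compounds shown here, this aromatic carbon does not accept every group equally: dimethylcarbamoyl in place of methyl gives an 8.6-fold higher number from compound 2 to compound 3 (0.93 log units; beyond the scatter), the first single-place step. The change adds heavy atoms and a hydrogen-bond acceptor, and the number rises, although this one pair cannot separate those two differences. Nothing available accounts for the step.

Going by these compounds, it remains open whether a primary carboxamide, a methoxy group or a carboxylic acid at this carbon would stay near compound 2 or fall near compound 3. On these data alone, the size of the step on the fluorinated aniline of compound 1 is also open.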